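Removing the Nitro Group from Compound 2

The compounds below may be only part of what the source reports. "The series", "measured", "known", "first", "only" and "open" are said of these compounds alone.

- Compound 1 `O=c1oc2ccccc2c2nc3c(ccc4cc[nH]c43)c(-c3cccc(Br)c3)c12` gives 70700 nM
- Compound 2 `O=c1oc2ccccc2c2nc3c(ccc4cc[nH]c43)c(-c3ccc([N+](=O)[O-])cc3)c12` gives 70700 nM

In a functional assay on B16-F10 cells (Mus musculus) for cytotoxicity (on this read-out higher numbers stand for weaker inhibition and lower numbers for stronger inhibition), compound 1 and compound 2 stand level at the digits shown, with compound 2 at 70700 nM. The next compound to be tested is compound 3 `O=c1oc2ccccc2c2nc3c(ccc4cc[nH]c43)c(-c3ccccc3)c12`, which has hydrogen in place of nitro on an aromatic carbon, para to a large group, so that 4-nitrophenyl becomes phenyl: hydrogen in place of nitro on an aromatic carbon. For the measured compounds named here, one measured step bears on this change, and only indirectly: no change at the digits printed from compound 1 to compound 2 (within the scatter). That step exchanged 3-bromophenyl for 4-nitrophenyl, and the read-out did not move beyond the scatter. Neither measured compound has an unsubstituted phenyl, so the data do not test this change directly. Going by the values given here, with only two values, both level, nothing points to a direction, and no step beyond the scatter is expected in this assay. The expected 1.1-fold lower number from compound 2 to compound 3 (0.04 log units; within the scatter) is an estimate that stays within the scatter. Compound 3 is therefore expected at about 65000 nM, with an estimated range from 30000 nM to 130000 nM.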

Compound 3, half-maximal inhibitory concentration: 70700 nM
Compound 3: middle estimate off by 1.1-fold (0.04 log units), on the low side; low and high end bracket the measured number.
By their numbers in this assay, from the lowest: compounds 1, 2 and 3 (each within the scatter of the next).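

For the compounds shown here, compound 3 supplies the unsubstituted phenyl that the earlier compounds lacked, so the change from 4-nitrophenyl to phenyl can now be read directly: in this assay, hydrogen in place of nitro gives no change at the digits printed from compound 2 to compound 3 (within the scatter). Hydrogen in place of bromo, the second single change that compound 3 opens, gives no change at the digits printed from compound 1 to compound 3 (within the scatter), so neither the nitro group of compound 2 nor the bromo group of compound 1 separates from the bare phenyl in this assay. Across these three compounds, the aromatic group on the shared core can therefore carry nitro, bromo or hydrogen with no difference beyond the scatter, and nothing available gives a reason for this level result.

The compounds shown leave open whether an amine, a carboxylic acid or a longer chain such as butoxy on this phenyl would also leave the number in place, or whether such a group would move it beyond the scatter. They also leave open what a change to the shared core itself would do, since compound 1, compound 2 and compound 3 differ only in this aromatic group.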